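Ethoxy added to the benzamide of compound 1

The source may report more compounds than this note shows. Statements on the series, on what has been measured and on what is new or still open speak of the compounds shown alone.

Within the data shown here, compound 1 `O=C(Nc1cc(Br)cc2c(=O)cc(C(=O)O)oc12)c1ccccc1` is one of three compounds measured in an assay on CHO cells for agonist activity at G protein-coupled receptor GPR35 (Rattus norvegicus), read by a beta-galactosidase reporter and beta-arrestin recruitment, with a stated time of 90 min (on this read-out higher numbers stand for an effect only at larger amounts of compound and lower numbers for an effect already at smaller amounts), where compound 1 gives 2750 nM, the lowest of the three numbers. Compound 2 `O=C(Nc1cc(Cl)cc2c(=O)cc(C(=O)O)oc12)c1ccc([N+](=O)[O-])cc1` gives 3140 nM, a number within the scatter of that of compound 1, so the two are read as alike. Compound 3 `O=C1N/C(=N/c2ccccc2F)S/C1=C\c1ccc(C(=O)O)cc1`, built on a different core, gives 8000 nM, a number beyond the scatter above that of compound 1. Compound 4 `CCOc1ccc(C(=O)Nc2cc(Br)cc3c(=O)cc(C(=O)O)oc23)cc1` differs from compound 1 by ethoxy in place of hydrogen on an aromatic carbon. Among the measured compounds shown here, no measured pair shows this change, so its size is not known from the data. The addition is expected to lower the number somewhat, the step of a 1.8-fold lower number from compound 1 to compound 4 (0.26 log units; within the scatter) being estimated as small and possibly within the scatter. For compound 4 the estimate is 1500 nM, with a range from 400 nM to 6000 nM.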

Compound 4, half-maximal effective concentration: 1360 nM
Compound 4: the middle estimate sits 1.1-fold (0.04 log units) above what was measured; the range from low to high includes it.
By their numbers in this assay, from the lowest: compound 4; then compounds 1 and 2 (each within the scatter of the next); then compound 3.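

Ethoxy on an aromatic carbon of the benzamide ring, para to a large group, gives in this assay a 2.0-fold lower number from compound 1 to compound 4 (0.31 log units; beyond the scatter) and so provides the first step in the series that changes one place only. This shows that the position accepts an added ethoxy without loss and that the number responds to phenyl to 4-ethoxyphenyl, though only modestly. No measurement at hand accounts for this step.

Open, going by these compounds, is whether methoxy, a longer alkoxy chain or an amine at this carbon would move the number further. Also open, on these data alone, is whether ethoxy gives a similar step with chlorine on the core in place of bromine.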